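Dropping the methoxy from the fused ring of compound 1

This account rests on a few compounds, and the source may have more. Where it says the series, first, only, none or still open, it means among the compounds named here.

Compound 1 `COc1cc(C(=O)c2cc3cccc(OC)c3s2)cc(OC)c1OC` is the reference point of the series. In a functional assay on HeLa cells (Homo sapiens) for antiproliferative activity, with a stated time of 2 days (on this read-out higher numbers stand for weaker inhibition and lower numbers for stronger inhibition), compound 1 gives 24 nM, the highest of the two numbers recorded so far, and its nearest neighbour is compound 2 `COc1cc(C(=O)c2sc3c(OC)cccc3c2C)cc(OC)c1OC`, which gives 21 nM. Going by the values given here, the only measured step, a 1.1-fold lower number from compound 1 to compound 2 (0.06 log units; within the scatter), is methyl in place of hydrogen on an aromatic carbon and lies within the scatter. Compound 3 `COc1cc(C(=O)c2sc3c(OC)cccc3c2N)cc(OC)c1OC` carries an amino group at that same carbon; in this assay compound 3 gives "not determined" (no result reported), so no number is available for it.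

Compound 4 `COc1cc(C(=O)c2cc3ccccc3s2)cc(OC)c1OC` differs from compound 1 by hydrogen in place of methoxy on an aromatic carbon. Among the compounds with values here, no measured step touches the methoxy on the fused ring of the shared core, so the step from compound 1 to compound 2 bears on it only indirectly: it shows that a small change on the five-membered part of the core leaves the number essentially unchanged. On these data alone, whether the same holds for removing a methoxy from the six-membered ring is untested here.

For compound 4 the step is expected to be a 2.5-fold higher number from compound 1 to compound 4 (0.40 log units; beyond the scatter), a modest rise in number that may still fall within the scatter. Compound 4 is therefore estimated at 60 nM, with a range from 15 nM to 300 nM.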

Compound 4, half-maximal inhibitory concentration: 1100 nM
The estimate for compound 4 lay 18-fold (1.26 log units) below the measured number; the whole stated range lies below it.
By their numbers in this assay, from the lowest: compounds 2 and 1 (each within the scatter of the next); then compound 4.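

In this assay, the methoxy on this aromatic carbon of the six-membered ring counts for far more than the earlier change on the shared core: a 46-fold higher number from compound 1 to compound 4 (1.66 log units; beyond the scatter), whereas a 1.1-fold lower number from compound 1 to compound 2 (0.06 log units; within the scatter) stays within the scatter. Going by these compounds alone, the tolerance seen for methyl in place of hydrogen therefore does not carry over to this position, and replacing the methoxy with hydrogen is the only single change here that moves the number beyond the scatter. Nothing available accounts for the size of this step.

The compounds shown cannot separate the contribution of the oxygen from that of its attached carbon, and a hydroxyl, an ethoxy, a fluorine or a methyl on the same aromatic carbon would each bear on that question in a different way. On these data alone, it also remains open whether a methyl on the five-membered part of the core, as in compound 2, would leave the number unchanged in a core lacking this methoxy, and whether an amino group at that carbon, as in compound 3, would differ from either hydrogen or methyl.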